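The source may hold more compounds than are shown below. What is called first, only, known or untested is meant among the compounds shown, and "the series" means these compounds.

Working notes on the series. For the measured compounds named here, in a functional assay on the whole organism (strain Wistar albino) for inhibition, with Rattus norvegicus as the target, read by paw edema, with stated times of 1 h and 4 h, at a dose of 40 mg/kg by the oral route (on this read-out lower numbers stand for less inhibition and higher numbers for more inhibition at the one dose given (going by the name of the read-out)), compound 2 `Cc1nc(Cc2ccc(Cl)cc2)sc1C1SCC(=O)N1c1ccc(F)c(Cl)c1` gives 68.9% and stands at the top of the three numbers measured so far, though only by a margin within the scatter from compound 1 `Cc1nc(-c2ccc(Cl)cc2)sc1C1SCC(=O)N1c1ccc(F)c(Cl)c1`, which gives 65.1%; the step of a number 3.8 percentage points higher from compound 1 to compound 2 (within the scatter) therefore supports no order between the two. Compound 3 `Cc1nc(-c2ccc(Cl)cc2)sc1C1SCC(=O)N1c1ccc(Cl)cc1` gives 43.2%, the lowest of the three and beyond the scatter from compound 2.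

Compound 4 `Cc1nc(Cc2ccc(Cl)cc2)sc1C1SCC(=O)N1c1ccc(Cl)cc1` has not been measured. Relative to compound 2 the change is 4-chlorophenyl in place of 3-chloro-4-fluorophenyl on an amide-type nitrogen in a ring. The same change has one precedent, the step from compound 1 to compound 3, where a number 21.9 percentage points lower from compound 1 to compound 3 (beyond the scatter); that step bears directly on the present one. The remaining measured step, a number 3.8 percentage points higher from compound 1 to compound 2 (within the scatter), concerns another part of the molecule and gives no guide here.

A loss of similar size is expected for compound 4 in this assay, the step being estimated as a number 21.9 percentage points lower from compound 2 to compound 4 (beyond the scatter). The estimate for compound 4 in this assay is 47%, with a range from 35% to 60%.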

Compound 4, a percentage reported as inhibition, in the whole organism at one dose (the size of the read-out at that dose, not a potency): 53.9%
Beside the measured number, compound 4's estimate is 6.9 percentage points below it, within the range that was stated.
By their numbers in this assay, from the lowest: compound 3; then compound 4; then compounds 1 and 2 (each within the scatter of the next).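

In this assay, the loss on moving from 3-chloro-4-fluorophenyl to 4-chlorophenyl on the amide-type nitrogen in a ring is no longer a single observation, with a number 15 percentage points lower from compound 2 to compound 4 (beyond the scatter), so it holds on a second core: the same change on two cores in this assay, a number 21.9 percentage points lower (beyond the scatter) from compound 1 to compound 3 and a number 15 percentage points lower (beyond the scatter) from compound 2 to compound 4, 6.9 percentage points apart, within the scatter of two such steps. No pair among the compounds shown goes against this loss. The change to 4-chlorobenzyl from 4-chlorophenyl now gives a number 10.7 percentage points higher from compound 3 to compound 4 (beyond the scatter), although the size of this step cannot be told apart from that of the earlier step on the other core: the same change on two cores in this assay, a number 3.8 percentage points higher (within the scatter) from compound 1 to compound 2 and a number 10.7 percentage points higher (beyond the scatter) from compound 3 to compound 4, 6.9 percentage points apart, within the scatter of two such steps.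

The compounds shown leave open how a phenyl bearing only fluorine would read on that nitrogen. They also leave open how a longer chain than that of 4-chlorobenzyl, or an amine on its ring, would read.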